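The source may hold more compounds than are shown below. What is called first, only, known or untested is meant among the compounds shown, and "the series" means these compounds.

Compounds measured so far:
- compound 1, `COC(=O)C1=C(C)N=C(C)/C(=C(\O)OC)C1c1cccc([N+](C)(C)C)c1`: 50100 nM
- compound 2, `COC(=O)C1=C(C)N=C(C)/C(=C(\O)OC)C1c1ccc(I)cc1`: 22900 nM
- compound 3, `COC(=O)C1=C(C)N=C(C)/C(=C(\O)OC)C1c1cccc(C#N)c1`: 34.7 nM

All three were tested in a functional assay (muscle tissue) with Cavia porcellus as the target; a higher number here means that more compound is needed for the effect, a lower number that less compound is needed. Compound 3 stands lowest of the three numbers, and both gaps to it are far beyond the scatter: the change from compound 1 gives a 1400-fold lower number from compound 1 to compound 3 (3.16 log units; beyond the scatter), and the change from compound 2 gives a 660-fold lower number from compound 2 to compound 3 (2.82 log units; beyond the scatter).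

Compound 4, `COC(=O)C1=C(C)N=C(C)/C(=C(\O)OC)C1c1cccc(C(F)(F)F)c1`, keeps the shared core of compound 3 and differs at one place only: trifluoromethyl in place of cyano on an aromatic carbon. The group sits on an aromatic carbon of a six-membered aromatic ring of carbon only, meta to a large group.

Neither measured step bears directly on this change. Both show that what sits on this ring can move the number enormously, but they compare the cyano group with a trimethylammonium group or with an iodine at a different place, not with a trifluoromethyl group. Within the data shown here, there is no measured pair that swaps cyano for trifluoromethyl. With so little to go on, the expectation for compound 4 is a modest step, most likely a somewhat higher number, so a 2.3-fold higher number from compound 3 to compound 4 (0.36 log units; beyond the scatter) is the estimated step, with a wide range.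

Compound 4 is therefore expected to give about 80 nM in this assay, between 15 nM and 500 nM.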

Compound 4, half-maximal effective concentration: 74.1 nM
Compound 4: middle estimate off by 1.1-fold (0.03 log units), on the high side, and the stated range covers the measured number.
By their numbers in this assay, from the lowest: compound 3; then compound 4; then compound 2; then compound 1.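

Among these compounds, on this aromatic carbon, cyano is not the only group that gives a low number in this assay: trifluoromethyl gives a 2.1-fold higher number from compound 3 to compound 4 (0.33 log units; beyond the scatter), a modest step even though the group that enters has more heavy atoms and counts no hydrogen-bond acceptor, while the cyano group that leaves counts one. The new comparison with the trimethylammonium group of compound 1 gives a 680-fold lower number from compound 1 to compound 4 (2.83 log units; beyond the scatter), a large step between two groups with the same count of heavy atoms, so that count alone does not set the number here. Nothing measured here explains either step.

The compounds shown leave open how far this tolerance extends, since only cyano, trifluoromethyl and trimethylammonium are compared on this carbon, and an amine, a carboxylic acid, a methoxy group or a plain hydrogen could each fall on either side of the large gap. They also leave open whether trifluoromethyl would keep a low number on another carbon of the ring, where iodine in compound 2 offers no direct comparison.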